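A few compounds are considered here, and "the series" means these few. Any claim that something is new, unique, unknown or untested is made for them only; others in the source may bear on it.

Compound 2, `COc1cc(-c2cc(/C=C/C(=O)c3ccc(Cl)c(Cl)c3)[nH]n2)cc(OC)c1OC`, is the starting point of this account. Within the data shown here, in a functional assay on KM12 cells (Homo sapiens) for cytotoxicity, read by sulforhodamine B assay, with a stated time of 48 h, tested at 100 uM (a lower number here means a stronger effect, a higher number a weaker effect of the compound at the concentration tested), compound 2 gives 3%, the highest of the three numbers measured so far and therefore the weakest effect among them. Its nearest neighbour is compound 3, `COc1ccc(C(=O)/C=C/c2cc(-c3cc(OC)c(OC)c(OC)c3)n[nH]2)cc1`, which in this assay gives -74%; furthest away stands compound 1, `COc1ccc(-c2cc(/C=C/C(=O)c3ccc(N)cc3)[nH]n2)cc1`, which in this assay gives -78%.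

The compound that has not yet been measured is compound 4, `COc1cc(-c2cc(/C=C/C(=O)c3ccc(F)c(F)c3)[nH]n2)cc(OC)c1OC`. It differs from compound 2 in one place: 3,4-difluorophenyl in place of 3,4-dichlorophenyl on a carbonyl carbon.

Among the measured compounds shown here, only one measured step bears on this change, and it does so by place rather than by kind. The step from compound 2 to compound 3 also alters the group on the carbonyl carbon, and there the number fell by a number 77 percentage points lower from compound 2 to compound 3 (beyond the scatter). That step, however, replaced the dichlorophenyl with a methoxyphenyl, whereas compound 4 keeps a dihalogenated phenyl. Compound 1 differs from compound 2 in two places, so its value cannot be tied to this single change.

For the measured compounds named here, with no measured pair that swaps one halogen for another, the expectation for compound 4 is held loosely: a step of a number 18 percentage points lower from compound 2 to compound 4 (beyond the scatter) is estimated, with the possibility that it stays within the scatter. Compound 4 is therefore expected to give -15% in this assay, within a range of -65% to 10%.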

Compound 4, a percentage reported as activity, at one concentration (the size of the read-out at that concentration, not a potency): -48%
Beside the measured number, compound 4's estimate is 33 percentage points above it; the range from low to high includes it.
By their numbers in this assay, from the lowest: compounds 1 and 3 (each within the scatter of the next); then compound 4; then compound 2.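

Exchanging one halogen pair for another on the carbonyl carbon is enough to shift the read-out in this assay, with a number 51 percentage points lower from compound 2 to compound 4 (beyond the scatter) as 3,4-difluorophenyl replaces 3,4-dichlorophenyl, so this position responds to more than the move away from a dihalogenated phenyl that the earlier step showed. The change does not carry compound 4 to the level of the methoxyphenyl analogue, for there is a number 26 percentage points higher from compound 3 to compound 4 (beyond the scatter) when 3,4-difluorophenyl replaces 4-methoxyphenyl, and the three groups at this place therefore give three separate levels, each step beyond the scatter. Nothing measured here accounts for these differences.

Whether both fluorines are needed stays open, since a single-halogen group such as 4-fluorophenyl and a non-halogen pair such as 3,4-dimethylphenyl do not appear among the compounds shown, and neither does a phenyl carrying a carboxylic acid. All of these numbers also come from a single tested concentration, so they leave the potency of compound 4 and its relation to the other compounds at lower concentrations unknown.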